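The source may report more compounds than this note shows. Statements on the series, on what has been measured and on what is new or still open speak of the compounds shown alone.

Measured in a functional assay on HEK293 cells for antagonist activity at G-protein coupled receptor 52 (Homo sapiens), read by cAMP accumulation, with stated times of 15 min and 30 min; a lower number here means a stronger inhibitor, a higher number a weaker inhibitor:

compound 1 `COc1cccc(C(=O)/C=C/CCc2ccccc2)c1` gives 1490 nM
compound 2 `COc1ccc(C(=O)/C=C/CCc2ccccc2)cc1` gives 3870 nM
compound 3 `O=C(/C=C/CCc1ccccc1)c1cccc(-c2ccccc2)c1` gives 8130 nM

Compound 1 and compound 3 share a core and differ in one place: phenyl in place of methoxy on an aromatic carbon. That single change produced a 5.5-fold higher number from compound 1 to compound 3 (0.74 log units; beyond the scatter), a weakening that is clear of the usual scatter. Compound 2 is built from the same atoms as compound 1, joined differently; the difference between the two cores is not broken down here. Its number lies below that of compound 3 and above that of compound 1, and both gaps are beyond the scatter.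

Compound 4 `O=C(/C=C/CCc1ccccc1)c1ccc(-c2ccccc2)cc1` has not been measured. It stands to compound 2 as compound 3 stands to compound 1: phenyl in place of methoxy on an aromatic carbon. Here the entering group sits para to a large group, whereas in compound 3 it sits meta to a large group, so this is the same kind of change rather than the same one. With a single earlier example to go on, the step is expected to point the same way and to be of similar size, a 3.9-fold higher number from compound 2 to compound 4 (0.59 log units; beyond the scatter), resting on a 5.5-fold higher number from compound 1 to compound 3 (0.74 log units; beyond the scatter). Compound 4 is therefore expected near 15000 nM, most likely between 5000 nM and 40000 nM.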

Compound 4, half-maximal inhibitory concentration: 7640 nM
Estimate against measurement, compound 4: 2.0-fold (0.29 log units) above, within the range that was stated.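

In this assay, phenyl in place of methoxy on an aromatic carbon gives a 2.0-fold higher number from compound 2 to compound 4 (0.30 log units; within the scatter), a step too small to be told apart from repeat-measurement noise. The same change does not have the same size on the two cores: the same change on two cores in this assay, a 5.5-fold higher number (0.74 log units; beyond the scatter) from compound 1 to compound 3 and a 2.0-fold higher number (0.30 log units; within the scatter) from compound 2 to compound 4, 2.8-fold (0.44 log units) apart, beyond the scatter of two such steps. So a step measured on one core in this series cannot simply be carried over to another as a fixed amount, but these two pairs do not show why, and since the entering group also sits in a different place on each core, the effect of the core cannot be separated from the effect of that place.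

The compounds shown leave open how other groups in this place, such as an amine or a carboxylic acid, would compare with methoxy and phenyl on either core. They also leave open whether a longer chain leading to the unsubstituted phenyl ring would shift these numbers.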